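Isopropyl on the urea nitrogen of compound 3

The compounds below may be only part of what the source reports. "The series", "measured", "known", "first", "only" and "open" are said of these compounds alone.

Three members of the series have numbers in a functional assay on MGC-803 cells (Homo sapiens) for cytotoxicity, read by MTT assay, with a stated time of 72 h (a lower number here means a stronger inhibitor, a higher number a weaker inhibitor), so far. Compound 1 `NC(=O)N1CCN(C(=S)SCc2cn(Cc3ccccc3F)nn2)CC1` gives 11300 nM in this assay. Compound 2 `O=C(NCc1ccccc1)N1CCN(C(=S)SCc2cn(Cc3ccccc3F)nn2)CC1` gives 13300 nM in this assay. Compound 3 `NC(=O)N1CCN(C(=S)SCc2cn(Cc3ccc(F)cc3)nn2)CC1` gives 9330 nM in this assay, the lowest of the three numbers, though its gaps to compound 1 and to compound 2 both lie within the scatter. Compound 4 `CC(C)NC(=O)N1CCN(C(=S)SCc2cn(Cc3ccc(F)cc3)nn2)CC1` has not yet been measured in this assay. It differs from compound 3 by isopropyl in place of hydrogen on an amide-type nitrogen. Within the data shown here, the one measured step that touches this position is a 1.2-fold higher number from compound 1 to compound 2 (0.07 log units; within the scatter), a far larger group on the same amide-type nitrogen that left the number where it was. The step of a 1.2-fold lower number from compound 1 to compound 3 (0.08 log units; within the scatter) changes the aryl group instead and does not bear on this question. On that basis no step beyond the scatter is expected from the added isopropyl, and the estimated step is a 1.0-fold higher number from compound 3 to compound 4 (0.01 log units; within the scatter). Compound 4 is therefore expected to give about 9500 nM in this assay, with a range of 4000 nM to 22000 nM.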

Compound 4, half-maximal inhibitory concentration: 760 nM
For compound 4 the middle estimate is 13-fold (1.10 log units) above the measured one, outside the stated range (below it).
By their numbers in this assay, from the lowest: compound 4; then compounds 3, 1 and 2 (each within the scatter of the next).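

In this assay the urea nitrogen turns out to be a position that can move the number: isopropyl in place of hydrogen on this amide-type nitrogen gives a 12-fold lower number from compound 3 to compound 4 (1.09 log units; beyond the scatter) while benzyl on the same nitrogen, with 2-fluorophenyl in the molecule, gave only a 1.2-fold higher number from compound 1 to compound 2 (0.07 log units; within the scatter) and so hinted at nothing of the kind. The position therefore does not respond alike to every group placed on it, and the flat benzyl step does not carry over to isopropyl. Nothing measured here accounts for the result.

The isopropyl step is seen only with 4-fluorophenyl and the benzyl step only with 2-fluorophenyl, so the compounds shown do not separate the group on the nitrogen from the aryl partner. As far as these compounds go, how a straight propyl chain, a cyclopropyl or a tert-butyl on this nitrogen would read remains open.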